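The source may hold more compounds than are shown below. What is called first, only, known or untested is meant among the compounds shown, and "the series" means these compounds.

Compound 1 `COc1cc(-c2nc(SCc3cn(CC(=O)NC(=O)Nc4ccccn4)nn3)nc(Nc3cccc(C(F)(F)F)c3)c2C#N)cc(OC)c1OC`: in a functional assay on ECa-109 cells (Homo sapiens) for inhibition, read by MTT assay, with a stated time of 72 h (on this read-out lower numbers stand for stronger inhibition and higher numbers for weaker inhibition), compound 1 gives > 64000 nM, which is a limit of the assay rather than a number.
Compound 2 `COc1ccc(Nc2nc(SCc3cn(CC(=O)NC(=O)Nc4ccccn4)nn3)nc(-c3ccc(C)cc3)c2C#N)cc1`: in this assay compound 2 gives 5870 nM.
Compound 3 `COc1ccccc1Nc1nc(SCc2cn(CC(=O)NC(=O)Nc3ccccn3)nn2)nc(-c2ccc(C)cc2)c1C#N`: in this assay compound 3 gives 7850 nM.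

Compound 3 carries the higher of the two numbers, but the step of a 1.3-fold higher number from compound 2 to compound 3 (0.13 log units; within the scatter) lies within the scatter, so compounds 2 and 3 cannot be told apart. Compound 4 `Cc1ccc(-c2nc(SCc3cn(CC(=O)NC(=O)Nc4ccccn4)nn3)nc(Nc3cccc(C(F)(F)F)c3)c2C#N)cc1` differs from compound 3 by 3-(trifluoromethyl)phenyl in place of 2-methoxyphenyl on a nitrogen on an aromatic ring. For the measured compounds named here, no measured step tests this exchange directly: the only measured step, a 1.3-fold higher number from compound 2 to compound 3 (0.13 log units; within the scatter), merely shifted a methoxy group on the same ring and stayed within the scatter. Compound 1 also carries the 3-(trifluoromethyl)phenyl group on that nitrogen, yet it bears a different aryl group elsewhere, so it gives no clean comparison; compound 1 sits at the limit of > 64000 nM in this assay, at which 1 of the 3 values shown sits. Compound 4 is therefore expected to give a somewhat higher number, 15000 nM, within 5000 nM to 64000 nM. The expected step is a 1.9-fold higher number from compound 3 to compound 4 (0.28 log units; within the scatter).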

Compound 4, half-maximal inhibitory concentration: 32300 nM
Compound 4: the middle estimate sits 2.2-fold (0.33 log units) below what was measured, within the range that was stated.
By their numbers in this assay, from the lowest: compounds 2 and 3 (each within the scatter of the next); then compound 4. At a limit, above all of these: compound 1.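

In this assay, the aryl group on this nitrogen does matter, unlike the earlier shift of a methoxy group: 3-(trifluoromethyl)phenyl gives a 4.1-fold higher number from compound 3 to compound 4 (0.61 log units; beyond the scatter) and a 5.5-fold higher number from compound 2 to compound 4 (0.74 log units; beyond the scatter), both modest but beyond the scatter. The exchange on the aromatic carbon stays unresolved, as the floor of an at least 1.9-fold lower number from compound 1 to compound 4 (0.29 log units; that floor lies within the scatter) lies within the scatter. Compound 1 gives a limit of the assay and not a number: the limit of > 64000 nM in this assay, at which 1 of the 4 values shown sits.

Open, from the compounds shown here alone, is whether the trifluoromethyl group or its place on the ring drives this loss. A 3-methoxyphenyl or a plain phenyl on this nitrogen would help separate the two.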